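This account rests on a few compounds, and the source may have more. Where it says the series, first, only, none or still open, it means among the compounds named here.

Compounds measured in an assay for inhibition of Amine oxidase [flavin-containing] A (Homo sapiens), read by fluorescence and spectrophotometry, using microsomes, with stated times of 30 min and 20 min; a higher number here means a weaker inhibitor, a lower number a stronger inhibitor:
Compound 1 `Clc1cccc(-c2noc(-c3ccc(C4=NCCN4)cc3)n2)c1` gives 5470 nM.
Compound 2 `COc1cccc(-c2noc(-c3ccc(C4=NCCN4)cc3)n2)c1` gives 12000 nM.

Compound 2 stands highest of the two numbers; its nearest neighbour is compound 1, and the step of a 2.2-fold higher number from compound 1 to compound 2 (0.34 log units; beyond the scatter) is a modest one. Compound 3 `Cc1ccc(Cc2noc(-c3ccc(C4=NCCN4)cc3)n2)cc1` is not yet measured. It differs from compound 2 by 4-methylbenzyl in place of 3-methoxyphenyl on an aromatic carbon. Within the data shown here, no measured step bears on this kind of change: the only step known, a 2.2-fold higher number from compound 1 to compound 2 (0.34 log units; beyond the scatter), swaps one substituent on the aryl ring and leaves the aryl attachment itself untouched. The estimate for compound 3 in this assay is therefore uncertain and is taken as a step of a 1.3-fold higher number from compound 2 to compound 3 (0.10 log units; within the scatter), with the value of compound 3 expected at 15000 nM, in a range from 4000 nM to 60000 nM.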

Compound 3, half-maximal inhibitory concentration: 55500 nM
For compound 3 the middle estimate is 3.7-fold (0.57 log units) below the measured one, and the stated range covers the measured number.
By their numbers in this assay, from the lowest: compound 1; then compound 2; then compound 3.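

Replacing the directly attached aryl group with 4-methylbenzyl on this aromatic carbon, between two ring nitrogen atoms, weakens inhibition in this assay: the change brings a 4.6-fold higher number from compound 2 to compound 3 (0.67 log units; beyond the scatter) and a 10-fold higher number from compound 1 to compound 3 (1.01 log units; beyond the scatter). This position therefore responds more to exchange of the whole group, with the second step large, than the earlier chloro-to-methoxy swap alone could show. Nothing available explains this result.

Because 4-methylbenzyl differs from both aryl groups in more than one feature, the contributions of its methylene link and its methyl group remain unseparated. As far as these compounds go, how a phenethyl group or an aminophenyl group would behave here also remains open.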